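Adding Two Methoxy Groups: Expected Cytotoxicity of Compound 4

The compounds below may be only part of what the source reports. "The series", "measured", "known", "first", "only" and "open" are said of these compounds alone.

Compound 3 `COc1ccc(-c2c(C#N)c(N)n(/N=C/c3cn(-c4ccccc4)nc3-c3ccccc3)c(=O)c2C#N)cc1` was tested in an ADME assay on NIH3T3 cells (Mus musculus) for cytotoxicity, read by MTT assay (a higher number here means a weaker inhibitor, a lower number a stronger inhibitor), where compound 3 gives 50 ug/mL. Among the three measured compounds it carries the lowest number, but the others lie close: in this assay compound 2 `N#Cc1c(-c2ccc(Cl)cc2)c(C#N)c(=O)n(/N=C/c2cn(-c3ccccc3)nc2-c2ccccc2)c1N` gives 64 ug/mL and compound 1 `N#Cc1c(-c2ccccc2Cl)c(C#N)c(=O)n(/N=C/c2cn(-c3ccccc3)nc2-c2ccccc2)c1N` gives 84 ug/mL. The steps of a 1.3-fold lower number from compound 2 to compound 3 (0.11 log units; within the scatter) and a 1.7-fold lower number from compound 1 to compound 3 (0.23 log units; within the scatter) both fall within the scatter, so no ordering among the three can be claimed. The remaining step, a 1.3-fold lower number from compound 1 to compound 2 (0.12 log units; within the scatter), is likewise within the scatter.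

Compound 4 `COc1cc(-c2c(C#N)c(N)n(/N=C/c3cn(-c4ccccc4)nc3-c3ccccc3)c(=O)c2C#N)cc(OC)c1OC` has not been measured. It differs from compound 3 by 3,4,5-trimethoxyphenyl in place of 4-methoxyphenyl on an aromatic carbon. Going by the values given here, no measured step adds further methoxy groups to a phenyl ring that already carries one; the nearest precedent is the exchange of chloro for methoxy in a 1.3-fold lower number from compound 2 to compound 3 (0.11 log units; within the scatter), and every change at this position so far has stayed within the scatter. The expected step of a 1.1-fold lower number from compound 3 to compound 4 (0.05 log units; within the scatter) is therefore no change beyond the scatter. Compound 4 is estimated to give 45 ug/mL in this assay, with a range from 22 ug/mL to 95 ug/mL.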

Compound 4, half-maximal inhibitory concentration: 64 ug/mL
Beside the measured number, compound 4's estimate is 1.4-fold (0.15 log units) below it, and the stated range covers the measured number.
By their numbers in this assay, from the lowest: compounds 3, 2, 4 and 1 (each within the scatter of the next).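

At the aromatic carbon opposite the ring nitrogen, a group of 12 heavy atoms, 3,4,5-trimethoxyphenyl, entered in place of the 8 heavy atoms of 4-methoxyphenyl, and this assay printed a 1.3-fold higher number from compound 3 to compound 4 (0.11 log units; within the scatter). The same group in place of either chlorophenyl gave no change at the digits printed from compound 2 to compound 4 (within the scatter) and a 1.3-fold lower number from compound 1 to compound 4 (0.12 log units; within the scatter), so all four aryl groups shown at this position, including the first with three methoxy groups, lie within the scatter of one another. No measurement shown gives a reason for this flat result.

The phenyl rings shown carry only chloro or methoxy groups, so it remains open whether an amine, a carboxylic acid or a longer alkoxy chain on the ring would move the number beyond the scatter. As far as these compounds go, it also remains open whether any change elsewhere on the shared core would do so.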